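Ortho substituent swap on the anilino ring of the series

This account rests on a few compounds, and the source may have more. Where it says the series, first, only, none or still open, it means among the compounds named here.

Three compounds share one core. Compound 1 `Clc1ccccc1Nc1nc(-c2ccncc2)cs1` carries a chloro group; in a functional assay on RCC4 cells (Homo sapiens) for inhibition, read by XTT assay, with a stated time of 4 days (on this read-out lower numbers stand for stronger inhibition and higher numbers for weaker inhibition), compound 1 gives 28200 nM, the highest number of the three. Compound 2 `Cc1ccc(Nc2nc(-c3ccncc3)cs2)cc1C` gives 6610 nM in this assay and compound 3 `Cc1cc(C)cc(Nc2nc(-c3ccncc3)cs2)c1` gives 4570 nM in this assay; both of these lie beyond the scatter below compound 1. For the measured compounds named here, no pair of measured compounds differs in a single place, so no step has been measured directly.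

Compound 4 `FC(F)(F)c1ccccc1Nc1nc(-c2ccncc2)cs1` is not yet measured. It differs from compound 1 by trifluoromethyl in place of chloro on an aromatic carbon. Going by the values given here, nothing among the measured compounds shows what this exchange does in this assay; the dimethyl compounds 2 and 3 change the ring in other places and do not inform it. The step of a 1.4-fold lower number from compound 1 to compound 4 (0.15 log units; within the scatter) is therefore expected to stay within the scatter, with no preferred direction. For compound 4 the estimate in this assay is 20000 nM, between 5000 nM and 80000 nM.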

Compound 4, half-maximal inhibitory concentration: 40700 nM
Beside the measured number, compound 4's estimate is 2.0-fold (0.31 log units) below it, and the stated range covers the measured number.
By their numbers in this assay, from the lowest: compounds 3 and 2 (each within the scatter of the next); then compounds 1 and 4 (each within the scatter of the next).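

In this assay, for the compounds shown here, trifluoromethyl in place of chloro on an aromatic carbon, ortho to a large group, gives a 1.4-fold higher number from compound 1 to compound 4 (0.16 log units; within the scatter), the only direct step available. On this read-out the two groups cannot be told apart at this position, even though 4 heavy atoms enter where 1 heavy atom leaves. No supporting measurement bears on this result.

The compounds shown leave open whether a methoxy group, an amine or a carboxylic acid on this aromatic carbon would move the number beyond the scatter, and how hydrogen there would compare. They also leave open how chloro or trifluoromethyl would read on the ring carbons that carry the methyl groups in compound 2 and compound 3.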